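Benzoyl replacing 3-acetylphenyl on the sulfonamide nitrogen

The source may report more compounds than this note shows. Statements on the series, on what has been measured and on what is new or still open speak of the compounds shown alone.

The series shares the core of compound 1 `O=C(O)c1ccccc1NS(=O)(=O)c1ccc2nc(-c3ccccc3)c(-c3ccccc3)nc2c1`, a diphenyl-substituted bicyclic sulfonamide whose nitrogen carries a varying group. In an ADME assay on the whole organism for pharmacokinetics, with Homo sapiens as the target (on this read-out higher numbers stand for higher oral bioavailability and lower numbers for lower oral bioavailability), compound 1 gives 83.6%. Compound 2 `CC(=O)c1cccc(NS(=O)(=O)c2ccc3nc(-c4ccccc4)c(-c4ccccc4)nc3c2)c1` gives 96.9%, and compound 3 `COc1ccccc1NS(=O)(=O)c1ccc2nc(-c3ccccc3)c(-c3ccccc3)nc2c1` gives 100%. Compound 2 stands second of the three, within the scatter of compound 3 and beyond it from compound 1: a number 13.3 percentage points higher from compound 1 to compound 2 (beyond the scatter), while a number 3.1 percentage points higher from compound 2 to compound 3 (within the scatter).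

Compound 4 `O=C(NS(=O)(=O)c1ccc2nc(-c3ccccc3)c(-c3ccccc3)nc2c1)c1ccccc1` is not yet measured. It differs from compound 2 in one place: benzoyl in place of 3-acetylphenyl on a sulfonamide nitrogen.

Both measured steps on this nitrogen exchange one substituted phenyl for another, and they bear only loosely on the present change, which puts a benzoyl on the nitrogen. Exchanging 2-carboxyphenyl for 3-acetylphenyl moved the read-out modestly upward, exchanging 3-acetylphenyl for 2-methoxyphenyl left it within the scatter. Neither covers a benzoyl, so the expectation rests on the narrow spread of the three numbers and is held loosely.

Compound 4 is expected to give 85%, between 60% and 100%. Within the data shown here, that estimate corresponds to a step of a number 11.9 percentage points lower from compound 2 to compound 4 (beyond the scatter), downward but modest, with a wide range because the measured series offers no step from an aryl to an acyl on this nitrogen.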

Compound 4, oral bioavailability: 100%
For compound 4 the middle estimate is 15 percentage points below the measured one, within the range that was stated.
By their numbers in this assay, from the lowest: compound 1; then compounds 2, 3 and 4 (each within the scatter of the next).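

In this assay, the sulfonamide nitrogen accepts benzoyl as readily as the two aryl groups in the upper part of the series: the result is a number 3.1 percentage points higher from compound 2 to compound 4 (within the scatter) and no change at the digits printed from compound 3 to compound 4 (within the scatter), so benzamido in place of (3-acetylphenyl)amino gives a number that cannot be told apart from those of compound 2 and compound 3. Against the 2-carboxyphenyl group the result is a number 16.4 percentage points higher from compound 1 to compound 4 (beyond the scatter), which leaves compound 1 as the only one of the four set apart, now with three different groups on this nitrogen beyond the scatter from it. Nothing available on the series bears on what lies behind these numbers.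

Still open, from the compounds shown here alone, is how this assay responds to other groups on this nitrogen: a smaller acyl such as acetyl, a plain alkyl chain, or a benzoyl ring carrying a carboxylic acid or an amine. Also open, going by these compounds, is which change on this nitrogen, if any, would separate compound 2, compound 3 and compound 4 from one another.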